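One Oxygen Traded for Sulfur on an Amine Nitrogen

A few compounds are considered here, and "the series" means these few. Any claim that something is new, unique, unknown or untested is made for them only; others in the source may bear on it.

Measured so far:
Compound 1, `Cc1nc(S(C)(=O)=O)ccc1Oc1ncnc(OC2CCN(C(=O)OC(C)C)CC2)c1F`: 77%
Compound 2, `Cc1nc(S(C)(=O)=O)ccc1Oc1ncnc(OC2CCN(C(=O)SC(C)(C)C)CC2)c1F`: 76%

In a functional assay on isolated protein for inhibition of Glucose-dependent insulinotropic receptor (Rattus norvegicus), read by HTRF and cAMP accumulation (on this read-out higher numbers stand for larger maximal responses and lower numbers for smaller maximal responses), compound 1 gives 77%. Among the two numbers, compound 1 stands highest, with compound 2 nearest, and the step of a number 1 percentage points lower from compound 1 to compound 2 (within the scatter) lies within the scatter. Compound 3, `Cc1nc(S(C)(=O)=O)ccc1Oc1ncnc(OC2CCN(C(=S)OC(C)C)CC2)c1F`, has not yet been tested. The change is a group of 6 heavy atoms (4 carbon, 1 oxygen, 1 sulfur; no ring) in place of a group of 6 heavy atoms (4 carbon, 2 oxygen; no ring), on an amine nitrogen in a ring. For the measured compounds named here, only one measured step bears on it: the change from compound 1 to compound 2 also sits on this amine nitrogen and also puts one sulfur in place of one oxygen in a group of the same size, and there the step of a number 1 percentage points lower from compound 1 to compound 2 (within the scatter) was within the scatter. Going by the values given here, no other step shows how a sulfur entering here acts. For compound 3 the step of a number 2 percentage points lower from compound 1 to compound 3 (within the scatter) is therefore expected, a change not beyond the scatter. The estimate for compound 3 is 75%, within a range from 60% to 88%.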

Compound 3, largest response reached (reported as efficacy), in percent of the reference or control that the assay uses: 47%
Compound 3: middle estimate off by 28 percentage points, on the high side, and the stated range ends above it.
By their numbers in this assay, from the lowest: compound 3; then compounds 2 and 1 (each within the scatter of the next).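

On this amine nitrogen, putting sulfur in place of oxygen does not have one fixed outcome: with sulfur as the doubly bonded atom, this assay shows a number 30 percentage points lower from compound 1 to compound 3 (beyond the scatter), whereas with sulfur in the single-bonded link, the (tert-butyl)sulfanyl group gave a number 1 percentage points lower from compound 1 to compound 2 (within the scatter). The comparison between the two sulfur groups gives a number 29 percentage points lower from compound 2 to compound 3 (beyond the scatter), so where the sulfur stands within the group goes with a clear difference in maximal response, although these two groups also differ in their carbon part. Nothing available here explains the drop.

Going by these compounds, it remains open whether the lower response belongs to the doubly bonded sulfur alone or depends on the isopropoxy group beside it in the structure of compound 3. A tert-butoxy group or a dimethylamino group on that same sulfur-bearing carbon would bear on this question.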